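Amino in place of nitro on an azetidinone core

The source may report more compounds than this note shows. Statements on the series, on what has been measured and on what is new or still open speak of the compounds shown alone.

Compound 1 `COc1ccc(C2C(OC(C)=O)C(=O)N2c2cc(OC)c(OC)c(OC)c2)cc1` is the parent: in a functional assay on IMR-32 cells (Homo sapiens) for cytotoxicity (a lower number here means a stronger inhibitor, a higher number a weaker inhibitor), compound 1 gives 251 nM. Compound 2 `COc1ccc(C2C(OC(C)=O)C(=O)N2c2cc(OC)c(OC)c(OC)c2)cc1[N+](=O)[O-]` carries a nitro group on the same core, and in this assay compound 2 gives 123 nM, the lowest of the two single numbers here; its nearest neighbour is compound 1, and the step of a 2.0-fold lower number from compound 1 to compound 2 (0.31 log units; beyond the scatter) is modest but beyond the usual scatter. Compound 3 `COc1ccc(C2C(O)C(=O)N2c2cc(OC)c(OC)c(OC)c2)cc1[N+](=O)[O-]`, with a free hydroxyl in place of the acetate ester, has several entries rather than one number: in this assay compound 3 gives 38 nM; 41.4 nM (2 entries), as shown by the several entries of compound 3 in this assay, 38 nM; 41.4 nM (2 entries).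

Compound 4 `COc1ccc(C2C(OC(C)=O)C(=O)N2c2cc(OC)c(OC)c(OC)c2)cc1N` differs from compound 2 by one change, (amino in place of nitro on an aromatic carbon). Among the compounds with values here, no measured step swaps nitro for amino, so the only guide is the step from compound 1 to compound 2, which shows that a group at this aromatic carbon shifts the number modestly. An amino group is a different group from nitro, so the gain seen with nitro need not carry over, and a number closer to that of compound 1 seems as likely as one matching compound 2. Compound 4 is therefore expected to give about 200 nM, with a plausible range from 60 nM to 700 nM; the step of a 1.6-fold higher number from compound 2 to compound 4 (0.21 log units; within the scatter) is expected to be small, within or only just beyond the scatter.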

Compound 4, half-maximal inhibitory concentration: 73.1 nM
Compound 4: the middle estimate sits 2.7-fold (0.44 log units) above what was measured, and the stated range covers the measured number.
By their numbers in this assay, from the lowest: compounds 4 and 2 (each within the scatter of the next); then compound 1.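

In this assay, the swap at this aromatic carbon, ortho to a methoxy group, reads a 1.7-fold lower number from compound 2 to compound 4 (0.23 log units; within the scatter), so the data do not separate amino from nitro here, even though the two groups differ in size and in their counts of hydrogen-bond donors and acceptors. Measured against hydrogen on the same core, the amino group gives a 3.4-fold lower number from compound 1 to compound 4 (0.54 log units; beyond the scatter), and the nitro group gives a 2.0-fold lower number from compound 1 to compound 2 (0.31 log units; beyond the scatter), so the lower number seen earlier is not unique to nitro: at this position, in these two compounds, either group beats plain hydrogen. Nothing measured here says why two such different groups land within the scatter of each other.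

As far as these compounds go, it remains open whether other groups at this carbon, such as a methyl group, a fluorine atom or a carboxylic acid, would also give a lower number than hydrogen, which would show how little the choice of group matters here. Also open, from the compounds shown here alone, is whether the free hydroxyl of compound 3, which gives 38 nM; 41.4 nM (2 entries) with nitro on the ring, would give a similar number when paired with amino.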